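From vinyl to but-1-en-1-yl on a carbonyl carbon

The source may report more compounds than this note shows. Statements on the series, on what has been measured and on what is new or still open speak of the compounds shown alone.

In a functional assay on HeLa cells (Homo sapiens) for antiproliferative activity, read by MTT assay, with a stated time of 72 h (a lower number here means a stronger inhibitor, a higher number a weaker inhibitor), compound 1 (`CC/C=C/C(=O)Nc1cccc(Oc2nc(Nc3ccn(C)n3)nc3c2CSCC3)c1`) gives > 50000 nM as its reading, which is a limit and not a number. Compound 2 (`CC/C=C/C(=O)Nc1cccc(Oc2nc(Nc3cccc(OC)c3)nc3c2CSCC3)c1`) gives 27200 nM in the same test. Compound 3 (`C=CC(=O)Nc1cccc(Oc2nc(Nc3ccc(OC)nc3)nc3c2CSCC3)c1`) gives 26300 nM and so lies within the scatter of compound 2, which means that the two cannot be ranked.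

Compound 4 (`CC/C=C/C(=O)Nc1cccc(Oc2nc(Nc3ccc(OC)nc3)nc3c2CSCC3)c1`) keeps everything in compound 3 except one group: but-1-en-1-yl replaces vinyl on a carbonyl carbon (but-1-en-1-yl in place of vinyl on a carbonyl carbon). Among the measured compounds shown here, compound 2 already carries but-1-en-1-yl at that place, but no measured pair isolates this swap. For the measured compounds named here, the only measured step, an at least 1.8-fold lower number from compound 1 to compound 2 (0.26 log units; that floor lies within the scatter), concerns a different group, the one on a nitrogen on an aromatic ring, so it says little here. With no measured evidence for a shift, no step beyond the scatter is expected in this assay and neither direction is favoured. The expected step is a 1.1-fold higher number from compound 3 to compound 4 (0.04 log units; within the scatter) in this estimate. The upper side is bounded by the limit of > 50000 nM in this assay, at which 1 of the 3 values shown sits, so a limit reading remains possible. The estimated value for compound 4 is 29000 nM with an expected range from 13000 nM to 50000 nM in this test.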

Compound 4, half-maximal inhibitory concentration: 31200 nM
For compound 4 the middle estimate is 1.1-fold (0.03 log units) below the measured one, within the range that was stated.
By their numbers in this assay, from the lowest: compounds 3, 2 and 4 (each within the scatter of the next). At a limit, above all of these: compound 1.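

In this assay, the change on the carbonyl carbon can now be read on its own, in a pair of compounds that differ only there: but-1-en-1-yl in place of vinyl gives a 1.2-fold higher number from compound 3 to compound 4 (0.07 log units; within the scatter), so the two groups cannot be told apart at this place. With but-1-en-1-yl held in place, the group on the nitrogen can also be compared, and 6-methoxypyridin-3-yl in place of 3-methoxyphenyl gives a 1.1-fold higher number from compound 2 to compound 4 (0.06 log units; within the scatter), so these two cannot be told apart either. The comparison with 1-methyl-1H-pyrazol-3-yl in compound 1 rests on a limit and not a number, and it gives only an at least 1.6-fold lower number from compound 1 to compound 4 (0.20 log units; that floor lies within the scatter), a floor that does not separate the two groups: the limit of > 50000 nM in this assay, at which 1 of the 4 values shown sits.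

The compounds shown leave open whether a chain on the carbonyl carbon that ends in a dimethylamino group, or a longer carbon chain, would move the reading beyond the scatter. Also open, going by these compounds, is whether the swap from vinyl to but-1-en-1-yl reads the same with 3-methoxyphenyl or 1-methyl-1H-pyrazol-3-yl on the nitrogen, as vinyl appears here only with 6-methoxypyridin-3-yl.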